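A few compounds are considered here, and "the series" means these few. Any claim that something is new, unique, unknown or untested is made for them only; others in the source may bear on it.

In a functional assay on the whole organism (strain albino) with Mus musculus as the target, with a stated time of 4 h (a higher number here means that more compound is needed for the effect, a lower number that less compound is needed), compound 1, `COc1ccccc1Nc1nnc(Nc2nc(-c3ccc(Cl)cc3)cs2)s1`, gives 100 mg/kg. Going by the values given here, compound 2, `COc1ccccc1Nc1nnc(Nc2nc(-c3ccc([N+](=O)[O-])cc3)cs2)s1`, gives 300 mg/kg; the single change between them is a 3.0-fold higher number from compound 1 to compound 2 (0.48 log units; beyond the scatter). Among the compounds with values here, on these two numbers compound 2 stands highest, and its only neighbour is compound 1, whose number is lower by that same step.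

Compound 3, `COc1ccccc1Nc1nnc(Nc2nc(-c3ccccc3)cs2)s1`, has not yet been tested. It differs from compound 2 by hydrogen in place of nitro on an aromatic carbon.

Within the data shown here, one measured step bears on this change: a 3.0-fold higher number from compound 1 to compound 2 (0.48 log units; beyond the scatter), in which the nitro group arrived and the number rose. Compound 3 removes that nitro group again, so the expectation is a step in the opposite direction, of roughly the same modest size; what the remaining difference between chloro and hydrogen contributes is not known from these two compounds, so the range is kept wide. For compound 3 the expected step is a 2.0-fold lower number from compound 2 to compound 3 (0.30 log units; within the scatter). Compound 3 is therefore estimated at 150 mg/kg, with a plausible range from 50 mg/kg to 450 mg/kg.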

Compound 3, minimum effective dose: 300 mg/kg
Estimate against measurement, compound 3: 2.0-fold (0.30 log units) below, and the stated range covers the measured number.
By their numbers in this assay, from the lowest: compound 1; then compounds 2 and 3 (each within the scatter of the next).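

In this assay, taking the nitro group off this place on the aromatic ring gives no change at the digits printed from compound 2 to compound 3 (within the scatter), so the nitro group and a plain hydrogen cannot be told apart here, and the earlier rise cannot be read as something the nitro group adds. Putting hydrogen in place of chloro gives a 3.0-fold higher number from compound 1 to compound 3 (0.48 log units; beyond the scatter), which shows that the chloro compound is the one that stands apart: compound 1 needs less compound for the effect than either of the other two, and the steps to both lie beyond the scatter. No measurement at hand explains why chloro differs from the other two groups at this position.

Going by these compounds, with only chloro, nitro and hydrogen at this place, it remains open whether the lower number belongs to chloro alone or would also appear with another halogen such as bromine, or with a small carbon group such as methyl. An amine at the same place would show whether a quite different kind of group also falls level with compound 2 and compound 3 or moves away from them.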